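Notes on the step from compound 3 to compound 4

This account rests on a few compounds, and the source may have more. Where it says the series, first, only, none or still open, it means among the compounds named here.

The series is followed in an assay for inhibition of Pro-cathepsin H (Homo sapiens), read by fluorescence, tested at 50 uM; a higher number here means more inhibition at the concentration tested (going by the name of the read-out), a lower number less inhibition. Two compounds carry numbers. Compound 1 `COc1nc(OC)nc(Sc2ccccc2C(=O)O)n1` gives -14.3% in this assay. Compound 2 `COC(=O)c1ccccc1Oc1nc(OC)nc(OC)n1` gives -5.34% in this assay. Both of these sit at or near zero inhibition, and the two values lie within the scatter of each other, so neither can be set apart from the other. Compound 3 `O=c1nc(SCc2ccccc2)nc(SCc2ccccc2F)[nH]1` was run, but in this assay compound 3 is recorded as "not determined" (no result reported), so there is no single number to place it against compound 1 or compound 2; where it stands on inhibition is open.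

Compound 4 `O=c1nc(SCc2ccccc2)nc(SCC2CCC2)[nH]1` differs from compound 3 in one place: cyclobutyl in place of 2-fluorophenyl on a saturated chain carbon bound to a sulfur. Among the measured compounds shown here, no measured pair differs in this way, so there is no step to carry over. The two compounds with numbers show no inhibition beyond the scatter, and nothing in the data ties the change to a shift in either direction. The expectation for this assay is therefore a step that is none beyond the scatter, in no set direction. Compound 4 is estimated at 0% in this assay, with an expected range from -15% to 15%.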

Compound 4, a percentage reported as inhibition, at one concentration (the size of the read-out at that concentration, not a potency): 1.57%
Beside the measured number, compound 4's estimate is 1.6 percentage points below it; measured number inside the range.
By their numbers in this assay, from the lowest: compounds 1, 2 and 4 (each within the scatter of the next, the first and the last beyond it).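

In this assay, among the compounds shown here, compound 4 gives 1.57% but compound 3 has no number, so no step from compound 3 to compound 4 can be read. No measured evidence bears on this result. The compounds shown leave open whether replacing 2-fluorobenzyl with cyclobutylmethyl changes inhibition at all.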